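A few compounds are considered here, and "the series" means these few. Any claim that something is new, unique, unknown or untested is made for them only; others in the source may bear on it.

In a functional assay on the whole organism (strain Kunming) with Mus musculus as the target, in the formalin test, with a stated time of 0.5 h (a lower number here means that less compound is needed, a higher number that more compound is needed for the effect), compound 1 (`COc1cc(OC)c(OC)cc1/C=C/COC(=O)/C=C/c1c(OC)ccc(OC)c1OC`) is reported only as a limit, <= 80 mg/kg. Among the compounds with values here, compound 2 (`COc1cc(OC)c(OC)cc1/C=C/COC(=O)/C=C/c1cccc(Br)c1`) gives 113 mg/kg, the only exact number so far, and its rank against compound 1 stays open. Compound 3 (`COc1cc(OC)c(OC)cc1/C=C/COC(=O)/C=C/c1ccc(Cl)cc1`) differs from compound 2 in one place: 4-chlorophenyl in place of 3-bromophenyl on a double-bonded chain carbon bound to a double-bonded chain carbon. Within the data shown here, no measured step covers this change, so no shift beyond the usual scatter is expected in this assay, and the expectation rests on compound 2 at 113 mg/kg. The estimated change is a 1.1-fold lower number from compound 2 to compound 3 (0.05 log units; within the scatter). The expected value for compound 3 is 100 mg/kg, with an estimated range of 50 mg/kg to 200 mg/kg.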

Compound 3, dose for half-maximal effect: 108 mg/kg
Compound 3: middle estimate off by 1.1-fold (0.03 log units), on the low side, within the range that was stated.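

Within the data shown here, on a double-bonded chain carbon bound to a double-bonded chain carbon, 4-chlorophenyl in place of 3-bromophenyl is the first readable step: in this assay it gives a 1.0-fold lower number from compound 2 to compound 3 (0.02 log units; within the scatter). Swapping the halogen and moving it on the ring together therefore leaves the number within the scatter for this pair. Compound 1 is reported only as a limit: the limit of <= 80 mg/kg in this assay, at which 1 of the 3 values shown sits.

The two changes are made at once here, so neither can be read alone. From the compounds shown here alone, whether an amine or a carboxylic acid on this phenyl ring would move the number stays open.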